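The compounds below may be only part of what the source reports. "The series", "measured", "known", "first", "only" and "open" are said of these compounds alone.

Among the measured compounds shown here, compound 1 `Clc1ccc(C2CC(c3ccccc3)=NN2c2ccc(-c3ccccc3)nn2)cc1` is one of two compounds measured in a functional assay on A549 cells (Homo sapiens) for antiproliferative activity, read by MTT assay, with a stated time of 24 h (on this read-out lower numbers stand for stronger inhibition and higher numbers for weaker inhibition), and compound 1 gives 100000 nM, the highest of the two numbers. Its nearest neighbour is compound 2 `COc1ccc(C2CC(c3ccccc3)=NN2c2ccc(-c3ccccc3)nn2)c(OC)c1`, which in this assay gives 9560 nM. For the measured compounds named here, the only measured step is a 10-fold lower number from compound 1 to compound 2 (1.02 log units; beyond the scatter), a change of 2,4-dimethoxyphenyl in place of 4-chlorophenyl on a saturated ring carbon of the shared core. Compound 3 `COc1ccc(C2=NN(c3ccc(-c4ccccc4)nn3)C(c3ccc(Cl)cc3)C2)cc1` keeps the 4-chlorophenyl of compound 1 and instead carries the difference (methoxy in place of hydrogen on an aromatic carbon), on an aromatic carbon of a six-membered aromatic ring of carbon only, para to a large group; read one bond further out, phenyl becomes 4-methoxyphenyl. The step from compound 1 to compound 2 sits on a different ring, so it bears only loosely here; still, adding methoxy was the direction that lowered the number. A moderately lower number is expected for compound 3, as a 2.5-fold lower number from compound 1 to compound 3 (0.40 log units; beyond the scatter), giving an estimate of 40000 nM with a range from 10000 nM to 120000 nM.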

Compound 3, half-maximal inhibitory concentration: 100000 nM
Compound 3: middle estimate off by 2.5-fold (0.40 log units), on the low side, and the stated range covers the measured number.
By their numbers in this assay, from the lowest: compound 2; then compounds 1 and 3 (each within the scatter of the next).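

In this assay, methoxy in place of hydrogen on this aromatic carbon, which turns phenyl into 4-methoxyphenyl, gives no change at the digits printed from compound 1 to compound 3 (within the scatter) and so leaves the read-out where compound 1 already stood. Adding a methoxy group therefore does not lower the number at every place on the molecule: the drop seen in a 10-fold lower number from compound 1 to compound 2 (1.02 log units; beyond the scatter) came with a swap on a different ring and does not carry over to this position. Nothing measured here accounts for this flat result.

The compounds shown do not tell whether another group at this same place, such as an amine, a hydroxyl or a carboxylic acid, would move the number. As far as these compounds go, it also remains open whether methoxy here would matter if the other ring carried the groups of compound 2.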